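The source may report more compounds than this note shows. Statements on the series, on what has been measured and on what is new or still open speak of the compounds shown alone.

Measured compounds:
compound 1, `Nc1ccc2cccc(OC3CCC3)c2n1`: > 2000 nM
compound 2, `Nc1ccc2cccc(OC3CCCCC3)c2n1`: 361 nM
compound 3, `CCOCCOc1cccc2ccc(N)nc12`: > 2000 nM

In an assay on cells with melanin-concentrating hormone receptor 1 (Homo sapiens) as the target, read by radioligand binding (a higher number here means a weaker inhibitor, a lower number a stronger inhibitor), compound 3 gives > 2000 nM, which is a limit of the assay and not a number. Compound 1 sits at the same limit, with > 2000 nM. Both stand at the limit of > 2000 nM in this assay, at which 2 of the 3 values shown sit, so the measured numbers settle nothing between them. Compound 2, by contrast, gives 361 nM.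

Compound 4, `Nc1ccc2cccc(OCCC3CCCCC3)c2n1`, differs from compound 3 by cyclohexyl in place of ethoxy on a saturated chain carbon, two bonds along the chain from an oxygen on an aromatic ring. Among the compounds with values here, two measured steps bear on this. The step of an at least 5.5-fold lower number from compound 1 to compound 2 (0.74 log units; beyond the scatter) and the step of an at least 5.5-fold higher number from compound 2 to compound 3 (0.74 log units; beyond the scatter) both show the compound carrying a cyclohexyl on the oxygen with the lowest number among the three. The step that the two limits leave unreadable from compound 1 to compound 3 cannot be read. Within the data shown here, compound 4 brings cyclohexyl back, but at the end of a chain rather than on the oxygen itself, and no measured compound tests such a chain, so the expectation is uncertain. A move toward where compound 2 stands is expected, in the direction of a lower number, as an at least 5.0-fold lower number from compound 3 to compound 4 (0.69 log units; beyond the scatter). For compound 4 the estimate is 400 nM, between 80 nM and 2000 nM.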

Compound 4, half-maximal inhibitory concentration: 808 nM
Beside the measured number, compound 4's estimate is 2.0-fold (0.31 log units) below it; the range from low to high includes it.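

Swapping ethoxy for cyclohexyl on the saturated chain carbon, two bonds along the chain from an oxygen on an aromatic ring, gives an at least 2.4-fold lower number from compound 3 to compound 4 (0.39 log units; beyond the scatter) in this assay. The value of compound 3, > 2000 nM, is a limit of the assay and not a number, so this step has only a lower bound on its size. The new result shows that cyclohexyl need not sit on the oxygen itself for a measurable value to appear, since compound 2 gives 361 nM with the ring on the oxygen and compound 4 gives 808 nM with the ring at the end of a chain.

The compounds shown leave open whether the ring itself matters or whether a straight hexyl chain would serve equally well at this position. They also leave open how a shorter or longer link to the cyclohexyl, or an amine at the chain end, would change the value.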